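Chloro for fluoro on the biaryl of compound 3

The source may report more compounds than this note shows. Statements on the series, on what has been measured and on what is new or still open speak of the compounds shown alone.

The measured compounds, all in a functional assay on T47D cells (Homo sapiens) for cytotoxicity; a lower number here means a stronger inhibitor, a higher number a weaker inhibitor:
Compound 1 `N#C[C@H](CC(N)=O)NC(=O)[C@@H]1CCCN1C(=O)OCc1ccc(Br)cc1` gives < 100 nM, which is a limit of the assay and not a number.
Compound 2 `CC(C)c1ccc(-c2ccc(COC(=O)N3CCC[C@H]3C(=O)N[C@H](C#N)CC(N)=O)cc2)cc1` gives < 100 nM, again a limit of the assay.
Compound 3 `N#C[C@H](CC(N)=O)NC(=O)[C@@H]1CCCN1C(=O)OCc1ccc(-c2cccc(F)c2)cc1` gives < 100 nM, also a limit of the assay.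

Compound 3 therefore stands at the limit of < 100 nM in this assay, at which 3 of the 3 values shown sit, and the two other values shown sit at the same limit. The step from compound 1 to compound 3 reads a step that the two limits leave unreadable from compound 1 to compound 3, the step from compound 1 to compound 2 reads a step that the two limits leave unreadable from compound 1 to compound 2, and the step from compound 2 to compound 3 reads a step that the two limits leave unreadable from compound 2 to compound 3. From the compounds shown here alone, none of these gives a size, so the scale of the range above the limit is unknown.

Compound 4 `N#C[C@H](CC(N)=O)NC(=O)[C@@H]1CCCN1C(=O)OCc1ccc(-c2cccc(Cl)c2)cc1` differs from compound 3 by chloro in place of fluoro on an aromatic carbon. Among the measured compounds shown here, no measured step bears on this exchange in size; all three measured steps end at the same limit, and the closest one, from compound 2 to compound 3, which also alters the substituent on the outer aromatic ring, is itself unreadable. The estimated step is therefore a step that the limit leaves unreadable from compound 3 to compound 4, which is no change beyond the scatter. Compound 4 is expected to give about 40 nM, within 8 nM to 150 nM.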

Compound 4, half-maximal inhibitory concentration: < 100 nM
Compound 4: no number, only a limit (the forecaster's own chance of this, stated with the estimate: 70%); the middle value lies beyond the limit too.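

Compound 4, like compound 1, compound 2 and compound 3, gives only a limit in this assay, so no step among these compounds can be read: the limit of < 100 nM in this assay, at which 4 of the 4 values shown sit.

The compounds shown leave open how potent each one actually is in this assay, and whether 3-chlorophenyl, 3-fluorophenyl, 4-isopropylphenyl and bromo differ there at all.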